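Replacing pyridin-3-yl on the ring amine nitrogen

The source may report more compounds than this note shows. Statements on the series, on what has been measured and on what is new or still open speak of the compounds shown alone.

Measured in a functional assay on HeLa cells (Homo sapiens) for antiproliferative activity, read by CCK-8 assay, with a stated time of 72 h, tested at 2 uM; a lower number here means a weaker effect, a higher number a stronger effect of the compound at the concentration tested:
Compound 1 `Nc1ccccc1NC(=O)c1ccc(CSC(=S)N2CCN(c3ccccc3)CC2)cc1` gives 62.2%
Compound 2 `Nc1ccccc1NC(=O)c1ccc(CSC(=S)N2CCN(c3cccnc3)CC2)cc1` gives 66.2%

Going by the values given here, only these two compounds have numbers so far. Among the compounds with values here, compound 2 sits alongside compound 1, the two values lying within the usual scatter of each other, so neither can be called the stronger one; the single measured step is a number 4 percentage points higher from compound 1 to compound 2 (within the scatter), pyridin-3-yl in place of phenyl on an amine nitrogen in a ring.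

Compound 3 `COc1ccc(N2CCN(C(=S)SCc3ccc(C(=O)Nc4ccccc4N)cc3)CC2)cc1` has not yet been measured in this assay. It differs from compound 2 in one place: 4-methoxyphenyl in place of pyridin-3-yl on an amine nitrogen in a ring. Within the data shown here, the one measured step bears on it only loosely, since it also exchanges the group on that ring nitrogen, but it was within the scatter. On that basis no movement beyond the scatter is expected from compound 2 to compound 3; the estimated step is a number 3.2 percentage points lower from compound 2 to compound 3 (within the scatter). Compound 3 is therefore expected to give about 63%, with a range from 48% to 76%.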

Compound 3, a percentage reported as inhibition, at one concentration (the size of the read-out at that concentration, not a potency): 39.4%
Beside the measured number, compound 3's estimate is 23.6 percentage points above it; measured number outside the range, below it.
By their numbers in this assay, from the lowest: compound 3; then compounds 1 and 2 (each within the scatter of the next).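

In this assay the group on the ring amine nitrogen turns out not to be freely exchangeable, which the earlier pair of compound 1 and compound 2 could not show, since their aromatic rings gave values within the scatter of each other. Here 4-methoxyphenyl in place of pyridin-3-yl gives a number 26.8 percentage points lower from compound 2 to compound 3 (beyond the scatter) for that position, and the comparison with the plain phenyl ring gives a number 22.8 percentage points lower from compound 1 to compound 3 (beyond the scatter) on adding methoxy in place of hydrogen on an aromatic carbon, so this single substituent on the ring is enough to lower the read-out beyond the scatter, making compound 3 the lowest of the three. No supporting evidence bears on why this drop occurs.

The compounds shown leave open whether the drop belongs to methoxy in particular or would also follow from another substituent on that carbon, such as a methyl, a chlorine or a hydroxyl. On these data alone, it also remains open whether methoxy on a pyridin-3-yl ring would lower the read-out in the same way, or whether a benzyl group on the ring nitrogen would keep it at the level of compound 1 and compound 2.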